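From Ethoxy to Pyridinyl on a Sluggish Core

The compounds below may be only part of what the source reports. "The series", "measured", "known", "first", "only" and "open" are said of these compounds alone.

Within the data shown here, compound 3 `CCOc1n[nH]c2ncc(C#Cc3c(F)ccc(NS(=O)(=O)c4cccnc4)c3F)cc12` is the one member of this small set that returns a number rather than a limit: in a functional assay on HCT-116 cells (Homo sapiens) for antiproliferative activity, read by MTT assay, with a stated time of 68 h (on this read-out higher numbers stand for weaker inhibition and lower numbers for stronger inhibition), compound 3 gives 10000 nM. Compound 1 `O=S(=O)(Nc1ccc(F)c(C#Cc2cnc3[nH]ncc3c2)c1F)c1ccccc1` stops at a limit of the assay, and in this assay compound 1 gives > 10000 nM. Compound 2 `O=S(=O)(Nc1ccc(F)c(C#Cc2cnc3[nH]ccc3c2)c1F)c1cccnc1` also stops at a limit, and in this assay compound 2 gives > 10000 nM.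

Compound 4 `O=S(=O)(Nc1ccc(F)c(C#Cc2cnc3[nH]nc(-c4ccncc4)c3c2)c1F)c1cccnc1` differs from compound 3 by pyridin-4-yl in place of ethoxy on an aromatic carbon. Among the measured compounds shown here, no measured pair tracks this change, and the weight of the data sits at the limit of > 10000 nM in this assay, at which 2 of the 3 values shown sit. A modest strengthening is nonetheless expected, with the step estimated as a 2.5-fold lower number from compound 3 to compound 4 (0.40 log units; beyond the scatter). Compound 4 is accordingly estimated at 4000 nM, ranging from 800 nM to 12000 nM.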

Compound 4, half-maximal inhibitory concentration: > 10000 nM
Compound 4: no number, only a limit; the forecaster's own chance of this, stated with the estimate: 35%; middle value at least 2.5-fold (0.39 log units) away from the limit.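

Placing pyridin-4-yl on this aromatic carbon in place of ethoxy gives a number no lower from compound 3 to compound 4 (the limit leaves the size open) in this assay, so the size of the step cannot be read. A six-membered aromatic ring at this place therefore brings no readable gain over ethoxy. Compound 4 joins the compounds that stop at the limit: the limit of > 10000 nM in this assay, at which 3 of the 4 values shown sit.

From the compounds shown here alone, whether an amine or a longer alkoxy chain on this carbon would return a clearly lower number than compound 3 stays open. So does how far the true value of compound 4 lies past its limit.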